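Replacing the group on a sulfonamide nitrogen

The compounds below may be only part of what the source reports. "The series", "measured", "known", "first", "only" and "open" are said of these compounds alone.

Of the compounds shown here, three sharing a core have been measured in a physicochemical assay for lipophilicity; on this read-out lower numbers stand for lower lipophilicity and higher numbers for higher lipophilicity. Compound 3 `Cn1nccc1-c1cc(C(F)(F)F)ccc1[C@H]1CCOc2cc(S(=O)(=O)Nc3nccs3)ccc21` reads 2.2. That is level within the scatter with compound 2 `O=C1OCCN1c1cc(C(F)(F)F)ccc1[C@H]1CCOc2cc(S(=O)(=O)Nc3nccs3)ccc21` at 2.1, and well under compound 1 `Cc1nc(-c2cc(C(F)(F)F)ccc2[C@H]2CCOc3cc(S(=O)(=O)Nc4cccc(F)n4)ccc32)co1` at 4.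

Compound 4 `Cn1nccc1-c1cc(C(F)(F)F)ccc1[C@H]1CCOc2cc(S(=O)(=O)Nc3cccc(F)n3)ccc21` keeps the 1-methyl-1H-pyrazol-5-yl of compound 3 and alters the other end of the molecule, with 6-fluoropyridin-2-yl in place of 1,3-thiazol-2-yl on a sulfonamide nitrogen.

Among the measured compounds shown here, no measured step makes this exchange. The only one available, a number 0.10 log units higher from compound 2 to compound 3 (within the scatter), leaves 1,3-thiazol-2-yl untouched and concerns an aromatic carbon instead, so it says little here beyond showing that exchange staying within the scatter. For the measured compounds named here, the closer guide is compound 1 at 4, the one measured compound carrying 6-fluoropyridin-2-yl on the sulfonamide nitrogen. It also differs from compound 3 in a second place, so its gap cannot be read as the effect of this exchange alone, and a rise somewhat smaller than that gap seems the cautious reading.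

The expected move is a number 1.20 log units higher from compound 3 to compound 4 (beyond the scatter), upward and beyond the scatter. For compound 4 the estimated value is 3.4, with an expected range from 2.8 to 4.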

Compound 4, distribution coefficient: 3.6
For compound 4 the middle estimate is 0.20 log units below the measured one, within the range that was stated.
By their numbers in this assay, from the lowest: compounds 2 and 3 (each within the scatter of the next); then compound 4; then compound 1.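

In this assay, the change from 1,3-thiazol-2-yl to 6-fluoropyridin-2-yl on the sulfonamide nitrogen can now be read on its own, with the rest of the molecule unchanged, as a number 1.40 log units higher from compound 3 to compound 4 (beyond the scatter), so the group at this position alone can shift the read-out by a large step. With 6-fluoropyridin-2-yl held on that nitrogen, 1-methyl-1H-pyrazol-5-yl in place of 2-methyl-1,3-oxazol-4-yl on an aromatic carbon gives a number 0.40 log units lower from compound 1 to compound 4 (beyond the scatter), a modest step that shows the aromatic carbon also matters, though less than the sulfonamide exchange does in these pairs. No supporting data are available to explain the size or direction of either step.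

Among the compounds shown here, it remains open whether the sulfonamide exchange would give a step of the same size with 2-oxo-1,3-oxazolidin-3-yl or 2-methyl-1,3-oxazol-4-yl on the aromatic carbon, as only the pair carrying 1-methyl-1H-pyrazol-5-yl reads it directly. The compounds shown also leave open how other groups on the sulfonamide nitrogen, such as an unsubstituted pyridin-2-yl, a pyrimidin-2-yl or a plain phenyl, would read, and so whether the fluorine or the six-membered ring accounts for the rise.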